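This account rests on a few compounds, and the source may have more. Where it says the series, first, only, none or still open, it means among the compounds named here.

Compound 1 `NC1=NC2(CCSCC2)N(OCCCOc2cccc(Cl)c2)C(N)=N1`: 60 nM. Compound 2 `NC1=NC2(CCOCC2)N(OCCCOc2ccc(Cl)c(Cl)c2)C(N)=N1`: 790 nM. Compound 3 `NC1=NC2(CCSCC2)N(OCCCOc2cccc(Cl)c2Cl)C(N)=N1`: 1 nM.

In a functional assay on A549 cells (Homo sapiens) for antiproliferative activity, read by MTT assay, with a stated time of 72 h (on this read-out lower numbers stand for stronger inhibition and higher numbers for weaker inhibition), compound 2 gives the highest of the three numbers; compound 1 and compound 3 both lie well below it. Compound 4 `NC1=NC2(CCOCC2)N(OCCCOc2ccccc2Br)C(N)=N1` differs from compound 2 by 2-bromophenyl in place of 3,4-dichlorophenyl on an oxygen on a saturated carbon. Among the compounds with values here, the only measured step, a 60-fold lower number from compound 1 to compound 3 (1.78 log units; beyond the scatter), shows how strongly the halogen pattern on the phenyl can move the number, but it adds a halogen, whereas compound 4 carries one halogen where compound 2 carries two and shifts its position. Within the data shown here, since no measured pair mirrors this change, the direction is uncertain, and a step near the scatter or somewhat higher is expected: a 1.5-fold higher number from compound 2 to compound 4 (0.18 log units; within the scatter). Compound 4 is therefore estimated at 1200 nM, with a range from 250 nM to 6000 nM.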

Compound 4, half-maximal inhibitory concentration: 160 nM
Beside the measured number, compound 4's estimate is 7.5-fold (0.88 log units) above it; measured number outside the range, below it.
By their numbers in this assay, from the lowest: compound 3; then compound 1; then compound 4; then compound 2.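

In this assay the exchange of 3,4-dichlorophenyl for 2-bromophenyl gives a 4.9-fold lower number from compound 2 to compound 4 (0.69 log units; beyond the scatter) at this position. A phenyl with one halogen can therefore give a lower number than one with two, while the earlier step, a 60-fold lower number from compound 1 to compound 3 (1.78 log units; beyond the scatter) on adding a chlorine, ran the other way, so halogen count alone does not set the number. Nothing measured here offers an explanation for this step.

On these data alone, whether the kind of halogen or its place carries the step remains open. So does how an unsubstituted phenyl, a carboxylic acid on the phenyl or a longer chain would fall.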